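Moving the fluorine on the phenyl ring of a hydantoin

The source may report more compounds than this note shows. Statements on the series, on what has been measured and on what is new or still open speak of the compounds shown alone.

Measured compounds:
- compound 1, `CC1(C)CC12NC(=O)N(NC(=O)c1ccccc1Cl)C2=O`: 300 mg/kg
- compound 2, `CC1(C)CC12NC(=O)N(NC(=O)c1ccc(F)cc1)C2=O`: 100 mg/kg

Both compounds were tested in a functional assay on the whole organism (Hindlimb) for inhibition, with Mus musculus as the target, with a stated time of 0.5 h; a higher number here means that more compound is needed for the effect, a lower number that less compound is needed. Compound 2 has the lowest of the two numbers; its nearest neighbour is compound 1, and the step of a 3.0-fold lower number from compound 1 to compound 2 (0.48 log units; beyond the scatter) lies beyond the scatter. Compound 3, `CC1(C)CC12NC(=O)N(NC(=O)c1ccccc1F)C2=O`, has not been measured yet. It differs from compound 2 in a single place: 2-fluorophenyl in place of 4-fluorophenyl on a carbonyl carbon.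

For the measured compounds named here, only one measured step bears on this change, and only partly: from compound 1 to compound 2 both the halogen and its position on the ring changed together, so the effect of the position alone cannot be separated. Since the 2-substituted ring of compound 1 gave the higher number, a modest rise in the number is expected for compound 3, estimated as a 2.0-fold higher number from compound 2 to compound 3 (0.30 log units; within the scatter). Compound 3 is therefore expected to give about 200 mg/kg, in a range from 100 mg/kg to 400 mg/kg.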

Compound 3, minimum effective dose: 100 mg/kg
The estimate for compound 3 lay 2.0-fold (0.30 log units) above the measured number, within the range that was stated.
By their numbers in this assay, from the lowest: compounds 2 and 3 (each within the scatter of the next); then compound 1.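

In this assay, the change from 4-fluorophenyl to 2-fluorophenyl on the carbonyl carbon gives no change at the digits printed from compound 2 to compound 3 (within the scatter), so with fluorine as the halogen, these two placements cannot be told apart. Compound 3 also separates the two changes that were mixed in the earlier step: with the ring placement held, fluoro in place of chloro on an aromatic carbon gives a 3.0-fold lower number from compound 1 to compound 3 (0.48 log units; beyond the scatter), so among these three compounds the difference follows the halogen and not its placement. No measured evidence here explains this difference.

Still open, as far as these compounds go, is whether a methoxy group or an amine in place of the fluorine would keep the number seen for compound 2 and compound 3. From the compounds shown here alone, whether the same reading holds outside this single whole-animal test also remains unknown.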